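The source may hold more compounds than are shown below. What is called first, only, known or untested is meant among the compounds shown, and "the series" means these compounds.

Two compounds of this series have readings in a physicochemical assay for solubility, measured as kinetic solubility, at pH 7.4, tested at 200 uM; a higher number here means a more soluble compound, a lower number a less soluble compound. Compound 1 `COc1ccc2c(=O)c(C)c(-c3cncc(-c4ccc(Cl)c(Cl)c4)c3)[nH]c2c1` gives 14000 nM. Compound 2 `COc1ccc2c(=O)c(C)c(-c3ccnc(-c4ccc(OC(F)(F)F)cc4)c3)[nH]c2c1` gives < 1000 nM, which is a limit of the assay and not a number. Compound 2 therefore stands at the limit of < 1000 nM in this assay, at which 1 of the 2 values shown sits, and its true position on the scale is not known.

Compound 3 `Cc1c(-c2ccnc(-c3ccc(OC(F)(F)F)cc3)c2)[nH]c2ccccc2c1=O` is the next structure to be read. It differs from compound 2 by hydrogen in place of methoxy on an aromatic carbon. That carbon belongs to a six-membered aromatic ring of carbon only, part of a fused or bridged system of two rings. The rest of the structure is unchanged.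

For the measured compounds named here, no measured pair isolates this change, so any expectation in this assay is weakly founded. A small rise is expected, of a size not clearly beyond the usual scatter, and a reading at the limit remains possible. The expected change is an at least 1.5-fold higher number from compound 2 to compound 3 (0.17 log units; that floor lies within the scatter). For compound 3 the estimated value is 1500 nM, with an expected range of 500 nM to 5000 nM.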

Compound 3, solubility: 2100 nM
The estimate for compound 3 lay 1.4-fold (0.15 log units) below the measured number, within the range that was stated.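

Hydrogen in place of methoxy on an aromatic carbon, on a six-membered aromatic ring of carbon only that is part of a fused or bridged system of two rings, gives the first one-place step in the series in this assay: an at least 2.1-fold higher number from compound 2 to compound 3 (0.32 log units; beyond the scatter). Compound 2 reads < 1000 nM, which is a limit of the assay and not a number. The step therefore fixes a floor and not a size, because only one end of it is a number: the limit of < 1000 nM in this assay, at which 1 of the 3 values shown sits.

On these data alone, the true size of the step stays open, as does whether the same change would read alike with the substitution pattern of compound 1, which differs from compound 3 in more than one place. Also open, as far as these compounds go, is how a group such as an amine or a carboxylic acid on this aromatic carbon would read in this assay against hydrogen and methoxy.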